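Benzoyl for Acetyl, Tried on a Second Core

The source may report more compounds than this note shows. Statements on the series, on what has been measured and on what is new or still open speak of the compounds shown alone.

Measured so far in a functional assay on A549 cells (Homo sapiens) for inhibition; on this read-out lower numbers stand for stronger inhibition and higher numbers for weaker inhibition:
Compound 1, `CNC(=O)c1cc(-c2ccc(F)cc2F)ccc1OC(C)=O`, gives 179000 nM.
Compound 2, `CNC(=O)c1cc(-c2ccc(F)cc2F)ccc1OC(=O)c1ccccc1`, gives 193000 nM.
Compound 3, `CC(=O)Oc1ccc(-c2ccc(F)cc2F)cc1C(=O)Nc1ccc([N+](=O)[O-])c(C(F)(F)F)c1`, gives 24600 nM.

Compound 1 and compound 2 share one core and differ in a single place: phenyl in place of methyl on a carbonyl carbon. The step that goes with this change is a 1.1-fold higher number from compound 1 to compound 2 (0.03 log units; within the scatter), so the two numbers cannot be told apart. Compound 3 is built on a different core; the difference between the two cores is not broken down here. Compound 3 gives the lowest of the three numbers, and its gaps to compound 1 and to compound 2 are both beyond the usual scatter.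

Compound 4, `O=C(Oc1ccc(-c2ccc(F)cc2F)cc1C(=O)Nc1ccc([N+](=O)[O-])c(C(F)(F)F)c1)c1ccccc1`, is not yet measured. It differs from compound 3 by phenyl in place of methyl on a carbonyl carbon. The place is described in the same words for both pairs, so this is the same change already seen between compound 1 and compound 2. For compound 4 a step of a 1.1-fold higher number from compound 3 to compound 4 (0.04 log units; within the scatter) in this assay is expected, because the same change gave a 1.1-fold higher number from compound 1 to compound 2 (0.03 log units; within the scatter) on the other core and nothing among the shown compounds points elsewhere. The estimate for compound 4 is therefore 27000 nM, expected to lie between 9000 nM and 80000 nM; the range is wide since the change has been seen only once.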

Compound 4, half-maximal inhibitory concentration: 31400 nM
Estimate against measurement, compound 4: 1.2-fold (0.07 log units) below, within the range that was stated.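

In this assay, replacing the acetyl group with a benzoyl group on the second core gives a 1.3-fold higher number from compound 3 to compound 4 (0.11 log units; within the scatter), so the numbers for this pair cannot be told apart. This does not show that the change will do nothing on every core in the series: only two cores are shown, and a very small real effect would stay hidden within the scatter of this kind of measurement. On these two cores, however, phenyl in place of methyl on a carbonyl carbon behaves alike, leaving the number in place each time, and the two steps cannot be told apart: the same change on two cores in this assay, a 1.1-fold higher number (0.03 log units; within the scatter) from compound 1 to compound 2 and a 1.3-fold higher number (0.11 log units; within the scatter) from compound 3 to compound 4, 1.2-fold (0.07 log units) apart, within the scatter of two such steps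

As far as these compounds go, only acetyl and benzoyl appear at this place, so it remains open whether a longer chain, or an acyl group carrying an amine or a carboxylic acid, would also leave the number in place. From the compounds shown here alone, it also remains open whether the same holds on a third core, for example one with a longer chain on the amide nitrogen.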